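The source may hold more compounds than are shown below. What is called first, only, known or untested is meant among the compounds shown, and "the series" means these compounds.

For the measured compounds named here, compound 1 `CCn1c(-c2cnc(C)nc2)nc2c(N[C@H]3CCN(C(=O)C4CCC4)C3)ncnc21` is one of three compounds measured in an ADME assay on the whole organism (Canis lupus familiaris, strain Beagle) for pharmacokinetics (a lower number here means slower removal, a higher number faster removal of the compound), where compound 1 gives 11 mL/min/kg. Of the three numbers this is the highest, but both gaps to the others lie within the usual scatter of such measurements: compound 3 `CCn1c(-c2ccc(C(F)(F)F)nc2)nc2c(O[C@H]3CCN(C(=O)[C@H]4C[C@@H](OC)C4)C3)ncnc21` gives 6.2 mL/min/kg, and compound 2 `CCn1c(-c2ccc(C(F)(F)F)nc2)nc2c(O[C@H]3CCN(C(=O)c4cocn4)C3)ncnc21` gives 5.6 mL/min/kg. Compound 4 `CCn1c(-c2cnc(C)nc2)nc2c(N[C@H]3CCN(C(=O)N4CC(OC)C4)C3)ncnc21` differs from compound 1 in a single place: 3-methoxyazetidin-1-yl in place of cyclobutyl on a carbonyl carbon. Going by the values given here, the one measured step that bears on a swap at a carbonyl carbon is a 1.1-fold higher number from compound 2 to compound 3 (0.04 log units; within the scatter), which left the number within the scatter, although that step involved other groups in other compounds. With only this to go on, the number for compound 4 is expected to stay close to that of compound 1, with no shift beyond the scatter, so the expected step is a 1.1-fold lower number from compound 1 to compound 4 (0.04 log units; within the scatter). Compound 4 is therefore estimated at 10 mL/min/kg, with a likely range from 5 mL/min/kg to 20 mL/min/kg.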

Compound 4, clearance: 9 mL/min/kg
Beside the measured number, compound 4's estimate is 1.1-fold (0.05 log units) above it; the measured number falls inside the stated range.
By their numbers in this assay, from the lowest: compounds 2, 3, 4 and 1 (each within the scatter of the next).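

Putting 3-methoxyazetidin-1-yl in place of cyclobutyl on the carbonyl carbon gives a 1.2-fold lower number from compound 1 to compound 4 (0.09 log units; within the scatter) in this assay, a step within the scatter. For the compounds shown here, this is the first direct reading of a swap at this position on the core of compound 1, as the earlier step at a carbonyl carbon was measured on a different core. Here, a group with more heavy atoms, a ring nitrogen and a hydrogen-bond acceptor leaves the clearance indistinguishable from that of the cyclobutyl compound, and no measurement shown offers an explanation for this result.

Still open, going by these compounds, is whether a group of a different kind at this position, such as a carboxylic acid or a longer chain, would move the number beyond the scatter. The compounds shown also leave open whether unsubstituted azetidin-1-yl would read the same as its methoxy-bearing counterpart.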